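The source may report more compounds than this note shows. Statements on the series, on what has been measured and on what is new or still open speak of the compounds shown alone.

Series notes. Compound 1 `CCN(CC)c1cc2[nH]c(C3CCCCC3)nc2cc1NC(=O)OCCOCCOC` is read in an ADME assay on Vero cells (Chlorocebus sabaeus) for cytotoxicity, read by resazurin assay, with a stated time of 3 days (on this read-out higher numbers stand for weaker inhibition and lower numbers for stronger inhibition), only as a limit: compound 1 gives > 100 ug/mL. Compound 2 `CN(C)c1cc2[nH]c(C3CCCCC3)nc2cc1NC(=O)c1ccc(F)cc1` likewise reaches only a limit in this assay, where compound 2 gives > 100 ug/mL. Thus (the limit of > 100 ug/mL in this assay, at which 2 of the 2 values shown sit), and compound 1 stands alongside the other measured compound at that limit. Compound 3 `CCN(CC)c1cc2[nH]c(C3CCCCC3)nc2cc1NC(=O)c1ccc(C)cc1` differs from compound 1 in one place: 4-methylphenyl in place of 2-(2-methoxyethoxy)ethoxy on a carbonyl carbon. Within the data shown here, no measured step is known. Compound 2, also carrying an amide, sits at a limit, and the step of a number no higher from compound 1 to compound 3 (the limit leaves the size open) is therefore expected to be none beyond the scatter. For compound 3 the value expected in this assay is 100 ug/mL (range 50 ug/mL to 200 ug/mL), most likely again a limit.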

Compound 3, half-maximal inhibitory concentration: > 100 ug/mL
Compound 3: only a limit was reported; the forecaster's own chance of this, stated with the estimate: 75%; the middle value sits exactly at the limit.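

No step can be read between compound 1 and compound 3 in this assay; both values are only limits. Whether the group on the carbonyl carbon changes this read-out stays open, with every compound shown at one limit: the limit of > 100 ug/mL in this assay, at which 3 of the 3 values shown sit.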